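Para-substituent swap on a shared core: methoxy to bromo

The source may hold more compounds than are shown below. What is called first, only, known or untested is meant among the compounds shown, and "the series" means these compounds.

Measured compounds:
compound 1 `Cc1nnc(SCC(=O)N/N=c2/scc(-c3ccccc3)n2-c2ccccc2)s1` — 197 ug/mL
compound 2 `Cc1nnc(SCC(=O)N/N=c2/scc(-c3ccc(Cl)cc3)n2-c2ccccc2)s1` — 253 ug/mL
compound 3 `COc1ccc(-c2cs/c(=N/NC(=O)CSc3nnc(C)s3)n2-c2ccccc2)cc1` — 300 ug/mL

All three were tested in an ADME assay on NIH3T3 cells (Mus musculus) for cytotoxicity, read by MTT assay, with a stated time of 24 h; on this read-out lower numbers stand for stronger inhibition and higher numbers for weaker inhibition. Compound 1 gives 197 ug/mL, compound 2 gives 253 ug/mL and compound 3 gives 300 ug/mL. Compound 3 sits at the upper end of these numbers, yet the steps of a 1.5-fold higher number from compound 1 to compound 3 (0.18 log units; within the scatter) and a 1.2-fold higher number from compound 2 to compound 3 (0.07 log units; within the scatter) are both within the scatter, so compound 3 is not set apart from the other two. The step of a 1.3-fold higher number from compound 1 to compound 2 (0.11 log units; within the scatter) is likewise within the scatter.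

Compound 4 `Cc1nnc(SCC(=O)N/N=c2/scc(-c3ccc(Br)cc3)n2-c2ccccc2)s1` has not been measured. It differs from compound 3 by bromo in place of methoxy on an aromatic carbon. Going by the values given here, no measured step introduces bromo, but the three steps at this same aromatic carbon — hydrogen to chloro, hydrogen to methoxy, chloro to methoxy — all stayed within the scatter, and chloro is the closest measured relative of bromo. Compound 4 is therefore expected to show a step of a 1.2-fold lower number from compound 3 to compound 4 (0.08 log units; within the scatter) that does not exceed the scatter, in the direction of the chloro compound. The estimate for compound 4 is 250 ug/mL, with a range from 150 ug/mL to 420 ug/mL.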

Compound 4, half-maximal inhibitory concentration: 55 ug/mL
Compound 4: middle estimate off by 4.5-fold (0.66 log units), on the high side, and the stated range ends above it.
By their numbers in this assay, from the lowest: compound 4; then compounds 1, 2 and 3 (each within the scatter of the next).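

In this assay the aromatic carbon that had tolerated hydrogen, chloro and methoxy without a step beyond the scatter proves sensitive to the substituent, since the change from 4-methoxyphenyl to 4-bromophenyl gives a 5.5-fold lower number from compound 3 to compound 4 (0.74 log units; beyond the scatter) and sets the bromo compound apart from the other two. Even the exchange of one halogen for another counts here, with a 4.6-fold lower number from compound 2 to compound 4 (0.66 log units; beyond the scatter) in the same direction as a 3.6-fold lower number from compound 1 to compound 4 (0.55 log units; beyond the scatter) for bromo in place of hydrogen, so the earlier steps did not show the full range of this position. Nothing available here accounts for why bromo alone stands apart.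

On these data alone, whether the lower number belongs to bromo alone or extends to iodo, an amine or a carboxylic acid at this carbon stays open. So does whether bromo on the other phenyl ring of the shared core would give a similar step.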